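This account rests on a few compounds, and the source may have more. Where it says the series, first, only, none or still open, it means among the compounds named here.

In a functional assay on CNE-2 cells (Homo sapiens) for antiproliferative activity, read by sulforhodamine B assay, with a stated time of 48 h (a higher number here means a weaker inhibitor, a lower number a stronger inhibitor), three compounds built on a shared core have been measured. Compound 1 (`COc1cccc(C=C(C(=O)/C=C/c2cccc(OC)c2OC)C(=O)/C=C/c2cccc(OC)c2OC)c1OC`) gives 400 nM, compound 2 (`COc1ccc(OC)c(/C=C/C(=O)C(=Cc2ccc(O)c(OC)c2)C(=O)/C=C/c2cc(OC)ccc2OC)c1`) gives 340 nM and compound 3 (`COc1ccc(OC)c(/C=C/C(=O)C(=Cc2ccc(OC)c(OC)c2)C(=O)/C=C/c2cc(OC)ccc2OC)c1`) gives 550 nM. Compound 3 therefore cannot be told apart from either of the other two, since its gaps to both lie within the scatter.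

Compound 4 (`COc1ccc(OC)c(/C=C/C(=O)C(=Cc2cc(OC)c(O)c(OC)c2)C(=O)/C=C/c2cc(OC)ccc2OC)c1`) is compound 3 with one group exchanged, on a double-bonded chain carbon bound to a double-bonded chain carbon: 4-hydroxy-3,5-dimethoxyphenyl in place of 3,4-dimethoxyphenyl on a double-bonded chain carbon bound to a double-bonded chain carbon. In words, 4-hydroxy-3,5-dimethoxyphenyl stands in place of 3,4-dimethoxyphenyl.

Among the compounds with values here, one measured step bears on this exchange: a 1.6-fold higher number from compound 2 to compound 3 (0.21 log units; within the scatter), where a methyl takes the place of a hydrogen on an oxygen on an aromatic ring. Within the data shown here, that step is small, and no measured step shows what the added methoxy group does on its own. A change beyond the scatter is therefore not expected in this assay, and the estimated change is a 1.4-fold lower number from compound 3 to compound 4 (0.14 log units; within the scatter). For compound 4 the expected value is 400 nM, with an estimated range from 200 nM to 800 nM.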

Compound 4, half-maximal inhibitory concentration: 450 nM
Estimate against measurement, compound 4: 1.1-fold (0.05 log units) below; the measured number falls inside the stated range.
By their numbers in this assay, from the lowest: compounds 2, 1, 4 and 3 (each within the scatter of the next).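

In this assay, placing 4-hydroxy-3,5-dimethoxyphenyl in place of 3,4-dimethoxyphenyl on a double-bonded chain carbon bound to a double-bonded chain carbon gives a 1.2-fold lower number from compound 3 to compound 4 (0.09 log units; within the scatter) and so this position takes the exchange without a change that can be told from scatter. Within the data shown here, the added methoxy, which no earlier step could show alone, stands in place of hydrogen on an aromatic carbon and gives a 1.3-fold higher number from compound 2 to compound 4 (0.12 log units; within the scatter) and so it too leaves the number within the scatter. Nothing measured here offers a reason for these small steps.

On these data alone, the aromatic groups compared at this position carry only hydroxy and methoxy, so what an amine or a carboxylic acid would do there stays open. No step shown moves the number beyond the scatter, so how far this position can change the result also remains unknown.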